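Piperazine urea series: two limit readings and a methyl swap

The source may report more compounds than this note shows. Statements on the series, on what has been measured and on what is new or still open speak of the compounds shown alone.

Measured so far:
compound 1 `O=C(Nc1nc2ccc(F)cc2s1)N1CCN(c2ccc(Cl)nn2)CC1` — > 10000 nM
compound 2 `O=C(Nc1ccc(OC(F)(F)F)cc1)N1CCN(c2ccc(-c3ccccc3)nn2)CC1` — > 10000 nM

In an assay on HEK293 cells for inhibition of transient receptor potential cation channel subfamily V member 1 (Homo sapiens), read by FLIPR (on this read-out lower numbers stand for stronger inhibition and higher numbers for weaker inhibition), compound 1 gives > 10000 nM, which is a limit of the assay and not a number. Compound 2 also gives > 10000 nM in this assay, again a limit. Compound 1 therefore stands at the edge of what can be read, as both values do (the limit of > 10000 nM in this assay, at which 2 of the 2 values shown sit). Compound 3 `Cc1cnnc(N2CCN(C(=O)Nc3nc4ccc(F)cc4s3)CC2)c1` differs from compound 1 by 5-methylpyridazin-3-yl in place of 6-chloropyridazin-3-yl on an amine nitrogen in a ring. Within the data shown here, no step between measured compounds is available for this exchange, so no shift beyond the scatter is expected; the change from compound 1 to compound 3 is estimated as a step that the limit leaves unreadable from compound 1 to compound 3, most likely another limit. Compound 3 is expected to give 20000 nM (range 5000 nM to 80000 nM) in this assay.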

Compound 3, half-maximal inhibitory concentration: > 10000 nM
Compound 3: only a limit was reported (the forecaster's own chance of this, stated with the estimate: 75%); the middle value lies beyond the limit too.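

No step can be read from compound 1 to compound 3: both stand at a limit in this assay. The compounds shown leave open which change, if any, would give a readable value in this assay.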